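Chloro-to-bromo swap on the benzamide ring

The compounds below may be only part of what the source reports. "The series", "measured", "known", "first", "only" and "open" are said of these compounds alone.

The series pairs a sulfonamide-bearing aniline with an aryl amide. Compound 1 `O=C(Nc1ccc(S(=O)(=O)Nc2cccc(Cl)c2)cc1)c1ccc(Cl)cc1Cl` gives 575 nM in a functional assay on HEK293 cells for agonist activity at probable G-protein coupled receptor 27 (Homo sapiens), read by a luciferase reporter and beta-arrestin recruitment, with a stated time of 10 min; on this read-out higher numbers stand for an effect only at larger amounts of compound and lower numbers for an effect already at smaller amounts. Compound 2 `Cc1cc(Cl)ccc1C(=O)Nc1ccc(S(=O)(=O)Nc2ccccc2)cc1` gives 912 nM in this assay; the two numbers lie within the scatter of each other, so neither compound can be set apart from the other on what is shown.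

Compound 3 `Cc1cc(Br)ccc1C(=O)Nc1ccc(S(=O)(=O)Nc2ccccc2)cc1` differs from compound 2 in one place: bromo in place of chloro on an aromatic carbon. Among the measured compounds shown here, no measured pair in the set shows this change, so its size cannot be read off from data; an exchange of one halogen for the next of this kind is expected to shift this assay by no more than the scatter, in no fixed direction.

For compound 3 the expected step from compound 2 is a 1.1-fold lower number from compound 2 to compound 3 (0.06 log units; within the scatter), taken as within the scatter. Compound 3 is therefore estimated at 800 nM in this assay, with a range from 300 nM to 2500 nM.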

Compound 3, half-maximal effective concentration: 851 nM
Compound 3: middle estimate off by 1.1-fold (0.03 log units), on the low side; measured number inside the range.
By their numbers in this assay, from the lowest: compounds 1, 3 and 2 (each within the scatter of the next).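

Bromo and chloro on this ring cannot be told apart: the exchange of 4-chloro-2-methylphenyl for 4-bromo-2-methylphenyl gives a 1.1-fold lower number from compound 2 to compound 3 (0.03 log units; within the scatter) in this assay. This is the only pair shown that differs in one place, so it gives the series its first direct reading, which compound 1 and compound 2 could not give. At this carbon, meta to a methyl group and para to a large group, the read-out therefore does not separate these two halogens, and no measurement shown offers any explanation for that.

Still open, from the compounds shown here alone, is whether a group of another kind at this carbon, such as an amine or a carboxylic acid, would separate from compound 2 and compound 3. Also open, going by these compounds, is how a longer chain, such as ethyl, in place of the methyl group would read in this assay.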